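This account rests on a few compounds, and the source may have more. Where it says the series, first, only, none or still open, it means among the compounds named here.

Compound 2, with the structure `NC1=NC2(CCCCC2)N(c2ccccc2Cl)C(N)=N1`, stands in an assay for inhibition of Dihydrofolate reductase (Bos taurus), using NADPH (on this read-out higher numbers stand for weaker inhibition and lower numbers for stronger inhibition), only at a limit of the assay: compound 2 gives > 100000 nM. Its closest measured relative, compound 1, with the structure `NC1=NC2(CCCCC2)N(c2ccccc2)C(N)=N1`, is likewise reported only as a limit, and in this assay compound 1 gives > 100000 nM. For the measured compounds named here, the single measured step, a step that the two limits leave unreadable from compound 1 to compound 2, therefore has no readable size, because of the limit of > 100000 nM in this assay, at which 2 of the 2 values shown sit.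

Compound 3, with the structure `Cc1ccccc1N1C(N)=NC(N)=NC12CCCCC2`, is the next compound, and it differs from compound 2 by methyl in place of chloro on an aromatic carbon. Going by the values given here, the only measured step that bears on this change is the one between compound 1 and compound 2, which gives neither a size nor a direction. What can be expected in this assay is therefore no step beyond the scatter, with compound 3 most likely remaining at the same limit as compound 2. The step expected for compound 3 is a step that the limit leaves unreadable from compound 2 to compound 3. For compound 3 the estimated value is 150000 nM, with a range from 30000 nM to 1000000 nM.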

Compound 3, half-maximal inhibitory concentration: > 100000 nM
Compound 3: no number, only a limit; the forecaster's own chance of this, stated with the estimate: 75%; the middle value is on the limit's open side.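

No step can be read among compound 1, compound 2 and compound 3, because all three are reported only as the same limit in this assay: the limit of > 100000 nM in this assay, at which 3 of the 3 values shown sit.

The compounds shown leave open how strongly each one actually inhibits, and whether hydrogen, chloro or methyl on the aromatic carbon makes any difference.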